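The source may report more compounds than this note shows. Statements on the series, on what has been measured and on what is new or still open speak of the compounds shown alone.

Among the measured compounds shown here, compound 2, `O=C(N/N=C/c1ccc(Cl)cc1)c1cccnc1Nc1cccc(C(F)(F)F)c1`, stands highest of the two numbers measured so far in a functional assay on the whole organism (strain Wistar) for inhibition, with Rattus norvegicus as the target, read by paw edema, with a stated time of 1 h, at a dose of 10 mg/kg by the intraperitoneal route (a higher number here means more inhibition at the dose given (going by the name of the read-out), a lower number less inhibition), where compound 2 gives 67.2%. For the measured compounds named here, its only neighbour on the numbers is compound 1, `O=C(N/N=C/c1cccc(F)c1)c1cccnc1Nc1cccc(C(F)(F)F)c1`, which in this assay gives 51.5%. Going by the values given here, the single measured step, a number 15.7 percentage points higher from compound 1 to compound 2 (beyond the scatter), came from 4-chlorophenyl in place of 3-fluorophenyl on a carbon with a double bond to nitrogen.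

Compound 3, `COc1cccc(/C=N/NC(=O)c2cccnc2Nc2cccc(C(F)(F)F)c2)c1`, differs from compound 2 by 3-methoxyphenyl in place of 4-chlorophenyl on a carbon with a double bond to nitrogen. Among the compounds with values here, no measured step involves a methoxy group anywhere on this series, so the step from compound 1 to compound 2 bears on the new change only loosely: it shows that exchanging the aryl group at this position can move the number beyond the scatter, but it does not tell in which direction a 3-methoxyphenyl would move it. Within the data shown here, the one modest step available gives little ground for expecting a large change in either direction, and a result near compound 2, perhaps somewhat lower, is the most likely outcome. Compound 3 is therefore expected to give about 58%, within a range from 40% to 75%. This amounts to an expected step of a number 9.2 percentage points lower from compound 2 to compound 3 (within the scatter), which lies within the usual scatter.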

Compound 3, a percentage reported as inhibition, in the whole organism at one dose (the size of the read-out at that dose, not a potency): 58.8%
Beside the measured number, compound 3's estimate is 0.8 percentage points below it; low and high end bracket the measured number.
By their numbers in this assay, from the lowest: compounds 1, 3 and 2 (each within the scatter of the next, the first and the last beyond it).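

The methoxy group is new to this position, and neither of its steps separates compound 3 from its neighbours in this assay: replacing 4-chlorophenyl with 3-methoxyphenyl gives a number 8.4 percentage points lower from compound 2 to compound 3 (within the scatter), and methoxy in place of fluoro on an aromatic carbon gives a number 7.3 percentage points higher from compound 1 to compound 3 (within the scatter). The 3-methoxyphenyl group thus brings an oxygen and a hydrogen-bond acceptor to this carbon with a double bond to nitrogen, yet compound 3 cannot be told apart from either compound 1 or compound 2, even though those two stay apart by a number 15.7 percentage points higher from compound 1 to compound 2 (beyond the scatter). Nothing available explains how these three aryl groups relate to the numbers they give.

The compounds shown leave open how much of the gap between compound 1 and compound 2 belongs to the kind of group and how much to where it sits on the ring, as each of the three aryl groups differs from the others in both respects. They also leave open what an amine or a carboxylic acid on this aryl ring, or a longer chain in place of the methoxy, would give in this assay.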